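Chloro in Place of Methyl on the Shared Core

The source may hold more compounds than are shown below. What is called first, only, known or untested is meant among the compounds shown, and "the series" means these compounds.

Of the compounds shown here, two have been measured in a functional assay on L1210 cells (Mus musculus) for cytotoxicity, with a stated time of 48 h; on this read-out higher numbers stand for weaker inhibition and lower numbers for stronger inhibition. Compound 1 `Cc1ccc(/C=C2\CCC/C(=C\c3ccccc3[N+](=O)[O-])C2=O)cc1` gives 7770 nM, the lower of the two numbers shown, while compound 2 `O=C1/C(=C/c2ccc(Cl)cc2)CCC/C1=C\c1ccc([N+](=O)[O-])cc1` gives 9410 nM, a gap that stays within the scatter. Compound 3 `O=C1/C(=C/c2ccc(Cl)cc2)CCC/C1=C\c1ccccc1[N+](=O)[O-]` differs from compound 1 in one place: chloro in place of methyl on an aromatic carbon. For the measured compounds named here, no measured pair shows this change on its own, so nothing in the numbers speaks for a shift either way. The expected step of a 1.1-fold higher number from compound 1 to compound 3 (0.04 log units; within the scatter) is therefore small, not beyond the scatter. On that basis compound 3 is estimated at 8500 nM, within a range from 4000 nM to 18000 nM.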

Compound 3, half-maximal inhibitory concentration: 9380 nM
Beside the measured number, compound 3's estimate is 1.1-fold (0.04 log units) below it, within the range that was stated.
By their numbers in this assay, from the lowest: compounds 1, 3 and 2 (each within the scatter of the next).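

For the compounds shown here, the step of a 1.2-fold higher number from compound 1 to compound 3 (0.08 log units; within the scatter) in this assay is the first direct reading of chloro in place of methyl on an aromatic carbon, with the rest of compound 1 unchanged. At this position, para to a large group, the 4-methylphenyl and 4-chlorophenyl compounds cannot be told apart in this read-out. Nothing measured here offers an explanation for this result. Going by these compounds, it remains open whether an amine, a carboxylic acid or a longer chain at this same position would give a number beyond the scatter.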